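A single fluoro substitution on compound 2

The source may hold more compounds than are shown below. What is called first, only, known or untested is meant among the compounds shown, and "the series" means these compounds.

Measured in a functional assay on A-375 cells (Homo sapiens) for inhibition, read by MTT assay, with a stated time of 4 days; on this read-out lower numbers stand for stronger inhibition and higher numbers for weaker inhibition:
Compound 1 `CN1C[C@@H]2C[C@H]1CN2c1ccc(-c2ccnc3c(-c4cccc5[nH]ncc45)c(-c4ccncc4)nn23)cc1` gives 202 nM
Compound 2 `CN1C[C@@H]2CC[C@H]1CN2c1ccc(-c2ccnc3c(-c4cccc5[nH]ncc45)c(-c4ccncc4)nn23)cc1` gives 185 nM

Compounds 1 and 2 share one core and differ only in the group on an aromatic carbon, where two six-membered non-aromatic rings replace two five-membered ones. The measured step is a 1.1-fold lower number from compound 1 to compound 2 (0.04 log units; within the scatter). In this assay compound 2, at 185 nM, therefore stands level with compound 1, and the numbers set no order between them.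

Compound 3 `CN1C[C@@H]2CC[C@H]1CN2c1ccc(-c2ccnc3c(-c4cccc5[nH]ncc45)c(-c4ccncc4)nn23)c(F)c1` keeps all of compound 2 except for one change: fluoro in place of hydrogen on an aromatic carbon. This places fluoro in place of hydrogen on an aromatic carbon, ortho to a large group. For the measured compounds named here, the only measured step available, a 1.1-fold lower number from compound 1 to compound 2 (0.04 log units; within the scatter), concerns a different change, and no fluoro compound has yet been measured. That step therefore offers weak guidance and no direction, so no shift beyond the scatter is expected. The step expected is a 1.0-fold higher number from compound 2 to compound 3 (0.01 log units; within the scatter), with wide uncertainty in either direction. For compound 3 the estimated value is 190 nM, with an expected range from 85 nM to 420 nM.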

Compound 3, half-maximal inhibitory concentration: 118 nM
Compound 3: middle estimate off by 1.6-fold (0.21 log units), on the high side; low and high end bracket the measured number.
By their numbers in this assay, from the lowest: compounds 3, 2 and 1 (each within the scatter of the next).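

In this assay, the step for fluoro in place of hydrogen is a 1.6-fold lower number from compound 2 to compound 3 (0.20 log units; within the scatter), so it leaves compound 3 level with compound 2, and the numbers set no order between them. For the compounds shown here, the earlier pair varied only the group of 9 heavy atoms and its smaller counterpart, whereas this result is the first reading on the six-membered aromatic ring of carbon only that carries that group: an aromatic carbon ortho to a large group and meta to the group of 9 heavy atoms can bear fluoro without the number moving beyond the scatter. Nothing at hand explains the value of compound 3 or says what the fluoro does there.

The compounds shown leave open whether a larger or different group on this same carbon, such as chloro, methyl, methoxy, nitrile or an amine, would also stay within the scatter or would move the number beyond it. They also leave open whether fluoro on another carbon of this ring, or fluoro on this carbon alongside the group of compound 1, would read the same way.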